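Hydroxamic acid series: aryl to benzyl on the ring nitrogen

The source may report more compounds than this note shows. Statements on the series, on what has been measured and on what is new or still open speak of the compounds shown alone.

Measured so far:
compound 1, `O=C(Nc1ccc2c(c1)CCCN2c1ccc(C(=O)NO)cc1)Nc1ccc(Cl)c(C(F)(F)F)c1`: 3400 nM
compound 2, `O=C(CCCCCCC(=O)Nc1ccc(NC(=O)Nc2ccc(Cl)c(C(F)(F)F)c2)cc1)NO`: 8100 nM
compound 3, `O=C(Nc1ccc(Nc2ncc(C(=O)NO)cn2)cc1)Nc1ccc(Cl)c(C(F)(F)F)c1`: > 10000 nM

In a functional assay on SK-HEP1 cells (Homo sapiens) for inhibition, read by sulforhodamine B assay, with a stated time of 48 h (a higher number here means a weaker inhibitor, a lower number a stronger inhibitor), compound 1 gives 3400 nM, the lowest of the two numbers reported. Compound 2 gives 8100 nM, a gap from compound 1 that lies beyond the usual scatter. Compound 3 sits at a limit of the assay rather than at a number, > 10000 nM (the limit of > 10000 nM in this assay, at which 1 of the 3 values shown sits). Among the measured compounds shown here, none of these three compounds differ from one another in a single place, so no measured step is available to anchor the change considered here.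

Compound 4, `O=C(Nc1ccc2c(c1)CCCN2Cc1ccc(C(=O)NO)cc1)Nc1ccc(Cl)c(C(F)(F)F)c1`, has not yet been measured. It differs from compound 1 in one place: 4-(hydroxycarbamoyl)benzyl in place of 4-(hydroxycarbamoyl)phenyl on a nitrogen on an aromatic ring in a ring. The shared core of compound 1 and the urea end of the molecule are untouched; only the group carrying the hydroxamic acid is moved out by one carbon from the ring nitrogen. For the measured compounds named here, nothing among the measured compounds tests this kind of change, so the direction is open. The step from compound 1 to compound 4 is expected to be a 1.4-fold lower number from compound 1 to compound 4 (0.13 log units; within the scatter), a modest move that may not exceed the scatter. Compound 4 is thus estimated to give 2500 nM in this assay, within a range from 800 nM to 8000 nM.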

Compound 4, half-maximal inhibitory concentration: 4500 nM
Compound 4: the middle estimate sits 1.8-fold (0.26 log units) below what was measured; low and high end bracket the measured number.
By their numbers in this assay, from the lowest: compounds 1, 4 and 2 (each within the scatter of the next, the first and the last beyond it). At a limit, above all of these: compound 3.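

In this assay, placing 4-(hydroxycarbamoyl)benzyl in place of 4-(hydroxycarbamoyl)phenyl on a nitrogen on an aromatic ring in a ring gives a 1.3-fold higher number from compound 1 to compound 4 (0.12 log units; within the scatter). The compounds shown earlier offered no single-place step, and this one shows that at this position, the group carrying the hydroxamic acid can take the additional carbon while compound 4 stays within the scatter of compound 1, so the series tolerates this change in the cell read-out. No measurement among the compounds shown bears on why this step is so small.

Going by these compounds, whether the same tolerance holds for a longer chain at this position in place of 4-(hydroxycarbamoyl)benzyl remains open, since a single step cannot show how far the group can be extended. Also open, on these data alone, is whether a carboxylic acid in place of the hydroxamic acid on this group would stay within the scatter of compound 1 and compound 4 in this assay.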